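Amine Substituent Swap on a Coumarin Amide Series

The compounds below may be only part of what the source reports. "The series", "measured", "known", "first", "only" and "open" are said of these compounds alone.

Measured compounds:
compound 1 `CC(C)=CCc1cc(C(=O)Nc2cc3ccc(OCCCNC(C)C)c(C)c3oc2=O)ccc1O`: 750 nM
compound 2 `CC(C)=CCc1cc(C(=O)Nc2cc3ccc(OCCCNCC(N)=O)c(C)c3oc2=O)ccc1O`: 2290 nM

In a functional assay on SK-BR-3 cells (Homo sapiens) for antiproliferative activity (on this read-out lower numbers stand for stronger inhibition and higher numbers for weaker inhibition), compound 2 gives the highest of the two numbers, with compound 1 the nearest. Compound 3 `CC(C)=CCc1cc(C(=O)Nc2cc3ccc(OCCCN[C@@H]4C[C@H]5CC[C@@H]4C5)c(C)c3oc2=O)ccc1O` differs from compound 2 by a group of 7 heavy atoms (7 carbon; 2 five-membered non-aromatic rings of carbon only) in place of a group of 4 heavy atoms (2 carbon, 1 nitrogen, 1 oxygen; no ring), on an amine nitrogen. Among the measured compounds shown here, only one measured step bears on this: a 3.1-fold higher number from compound 1 to compound 2 (0.48 log units; beyond the scatter), where a hydrocarbon group gave way to carbamoylmethyl. Restoring a hydrocarbon group on the amine nitrogen is therefore expected to reverse that step, giving a 3.5-fold lower number from compound 2 to compound 3 (0.55 log units; beyond the scatter). Compound 3 is estimated at 650 nM, within 280 nM to 1500 nM.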

Compound 3, half-maximal inhibitory concentration: 770 nM
Compound 3: middle estimate off by 1.2-fold (0.07 log units), on the low side; measured number inside the range.
By their numbers in this assay, from the lowest: compounds 1 and 3 (each within the scatter of the next); then compound 2.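

In this assay, among the compounds shown here, the group of 7 heavy atoms on the amine nitrogen gives a 3.0-fold lower number from compound 2 to compound 3 (0.47 log units; beyond the scatter) and so shows that isopropyl is not the only hydrocarbon group that reads lower than carbamoylmethyl at this position. Set against isopropyl, the same group gives a 1.0-fold higher number from compound 1 to compound 3 (0.01 log units; within the scatter) and so cannot be told apart from it, despite its 2 five-membered non-aromatic rings. The compounds shown leave open how a carboxymethyl or a phenyl group on this amine nitrogen would read. No evidence is at hand on why the two hydrocarbon groups read alike.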